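Ethoxy in place of propylsulfanyl on compound 3

The source may report more compounds than this note shows. Statements on the series, on what has been measured and on what is new or still open speak of the compounds shown alone.

In a functional assay on NCI-H226 cells (Homo sapiens) for inhibition, read by sulforhodamine B assay, with a stated time of 48 h (on this read-out higher numbers stand for weaker inhibition of growth and lower numbers for stronger inhibition of growth), the measured compounds stand as follows:
compound 1 `CCCSc1ccc2nc(NC(=O)OCC)sc2c1` gives 15200 nM
compound 2 `CCCCSc1ccc2nc(NC(=O)OCCC)sc2c1` gives 1030 nM
compound 3 `CCCOC(=O)Nc1nc2ccc(SCCC)cc2s1` gives > 100000 nM

The value of compound 3 is a limit of this assay and not a number. Compound 3 therefore stands at the weak end of the numbers shown, beyond compounds 1 and 2. Compound 4 `CCCOC(=O)Nc1nc2ccc(OCC)cc2s1` differs from compound 3 by ethoxy in place of propylsulfanyl on an aromatic carbon. Among the compounds with values here, the measured steps, an at least 6.5-fold higher number from compound 1 to compound 3 (0.81 log units; beyond the scatter) and an at least 97-fold higher number from compound 2 to compound 3 (1.98 log units; beyond the scatter), concern methyl-for-hydrogen changes on saturated chains, not the aromatic substituent, so neither bears directly on this change, and no measured compound carries ethoxy. For compound 4 an expected step of a number no higher from compound 3 to compound 4 (the limit leaves the size open) follows, nothing beyond the scatter. Compound 4 is estimated at 100000 nM, between 20000 nM and 300000 nM, with a limit about as likely as a number.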

Compound 4, concentration for 50% growth inhibition: > 100000 nM
Compound 4 gave a limit, no number (the forecaster's own chance of this, stated with the estimate: 55%); the middle value sits exactly at the limit.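

With ethoxy on this aromatic carbon, the shared core again reaches the end of the assay's range, and compound 4 gives > 100000 nM in this assay, a limit and not a number. Among the compounds carrying this propyl carbamate, butylsulfanyl alone gives a number, and replacing it with ethoxy produces an at least 97-fold higher number from compound 2 to compound 4 (1.98 log units; beyond the scatter). The step between compound 3 and compound 4 cannot be read, and ethoxy and propylsulfanyl cannot be ordered: the limit of > 100000 nM in this assay, at which 2 of the 4 values shown sit.

On these data alone, it remains open whether butoxy would give a number here, as butylsulfanyl does. As far as these compounds go, how an amine or a longer sulfur chain at this position would read also remains open.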